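Swapping Methoxy for Chloro on the Pendant Phenyl

The source may report more compounds than this note shows. Statements on the series, on what has been measured and on what is new or still open speak of the compounds shown alone.

Of the compounds shown here, two have been measured in a functional assay on SF-295 cells (Homo sapiens) for inhibition; on this read-out lower numbers stand for stronger inhibition of growth and higher numbers for weaker inhibition of growth. Compound 1 `O=C(/C=C/c1cccc(O)c1)c1cccc(-n2cc(-c3ccc(Cl)cc3)[nH]c2=O)c1` gives 1790 nM in this assay. Compound 2 `COc1ccc(-c2cn(-c3cccc(C(=O)/C=C/c4ccc(O)c(OC)c4)c3)c(=O)[nH]2)cc1` gives 13900 nM and thus stands as the higher of the two numbers, with compound 1 the nearer point. Compound 3 `COc1cc(/C=C/C(=O)c2cccc(-n3cc(-c4ccc(Cl)cc4)[nH]c3=O)c2)ccc1O` has not been measured; it differs from compound 2 by chloro in place of methoxy on an aromatic carbon. Because compound 1, which carries this chloro group, gives 1790 nM, a step toward stronger inhibition beyond the scatter is expected. Compound 3 is therefore estimated at 3500 nM, within a range from 1200 nM to 10000 nM, which means an expected step of a 4.0-fold lower number from compound 2 to compound 3 (0.60 log units; beyond the scatter).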

Compound 3, concentration for 50% growth inhibition: 10500 nM
The estimate for compound 3 lay 3.0-fold (0.48 log units) below the measured number; the measured number lies above the stated range.
By their numbers in this assay, from the lowest: compound 1; then compounds 3 and 2 (each within the scatter of the next).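

In this assay, 4-methoxyphenyl and 4-chlorophenyl cannot be told apart on this core, since the step between them stays within the scatter (a 1.3-fold lower number from compound 2 to compound 3 (0.12 log units; within the scatter)). The clear change instead comes with 4-hydroxy-3-methoxyphenyl in place of 3-hydroxyphenyl on the chain (a 5.9-fold higher number from compound 1 to compound 3 (0.77 log units; beyond the scatter)), a contrast the first two compounds could not show because they differ in two places. Nothing available explains either step.

As far as these compounds go, it remains open whether chloro and methoxy would also match on the 3-hydroxyphenyl chain. From the compounds shown here alone, it is also open whether an amine or a carboxylic acid at this place would shift the number.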